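A few compounds are considered here, and "the series" means these few. Any claim that something is new, unique, unknown or untested is made for them only; others in the source may bear on it.

Measured compounds:
compound 1, `Nc1ccccc1-c1cnc(C(=O)CCCCCCc2ccccc2)o1`, 750 nM
compound 2, `N#Cc1cccc(-c2cnc(C(=O)CCCCCCc3ccccc3)o2)c1`, 15 nM
compound 3, `NC(=O)c1ccc(-c2cnc(C(=O)CCCCCCc3ccccc3)o2)nc1`, 1.2 nM

All three share the same core and were tested in an assay (Rattus norvegicus) for inhibition of Fatty-acid amide hydrolase 1 (Homo sapiens); a higher number here means a weaker inhibitor, a lower number a stronger inhibitor. Compound 3 stands at the lowest number of the three, with compound 2 at a 13-fold lower number from compound 2 to compound 3 (1.10 log units; beyond the scatter) and compound 1 at a 630-fold lower number from compound 1 to compound 3 (2.80 log units; beyond the scatter), both well beyond the scatter, so compound 3 is the strongest inhibitor shown.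

Compound 4, `CC(=O)c1cnc(C(=O)CCCCCCc2ccccc2)o1`, is the next compound. Its difference from compound 3 is: acetyl in place of 5-carbamoylpyridin-2-yl on an aromatic carbon

Within the data shown here, no measured step swaps the aromatic group at this carbon for a small open-chain group; the measured steps of a 50-fold lower number from compound 1 to compound 2 (1.70 log units; beyond the scatter), a 630-fold lower number from compound 1 to compound 3 (2.80 log units; beyond the scatter) and a 13-fold lower number from compound 2 to compound 3 (1.10 log units; beyond the scatter) only swap one aromatic group for another, yet they show that what sits at this carbon moves the number a great deal. With the whole ring gone, a clearly weaker inhibitor is expected, though a large loss is not certain. The expected step is a 33-fold higher number from compound 3 to compound 4 (1.52 log units; beyond the scatter), and compound 4 is estimated at 40 nM, between 8 nM and 200 nM.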

Compound 4, inhibition constant: 2 nM
The estimate for compound 4 lay 20-fold (1.30 log units) above the measured number, and the stated range ends above it.
By their numbers in this assay, from the lowest: compounds 3 and 4 (each within the scatter of the next); then compound 2; then compound 1.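

Swapping the 5-carbamoylpyridin-2-yl group for the much smaller acetyl, which has no ring, gives a 1.7-fold higher number from compound 3 to compound 4 (0.22 log units; within the scatter) in this assay. An aromatic ring at this carbon is therefore not required for a number as low as that of compound 3. Acetyl also compares well with the other two aromatic groups, giving a 7.5-fold lower number from compound 2 to compound 4 (0.88 log units; beyond the scatter) and a 380-fold lower number from compound 1 to compound 4 (2.57 log units; beyond the scatter), so among these compounds the size of the group does not by itself set the number, and nothing available explains why these groups rank as they do.

The compounds shown leave open whether the carbonyl of the acetyl matters, which a plain ethyl group or a carboxylic acid at this carbon could test. They also leave open whether a longer open chain ending in a ketone would keep a number this low.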